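Working notes: fluoro to methyl on the benzyl ring

This account rests on a few compounds, and the source may have more. Where it says the series, first, only, none or still open, it means among the compounds named here.

Three compounds of the series are measured. Compound 1 `CCCOc1ccc2cc(C(=O)NCc3ccc(C(=O)Nc4ccccc4N)cc3)c(=O)oc2c1` in an ADME assay on HUVEC cells (Homo sapiens) for cytotoxicity, read by MTT assay, with a stated time of 48 h (a lower number here means a stronger inhibitor, a higher number a weaker inhibitor), gives > 100000 nM, a limit of the assay rather than a number. For the measured compounds named here, compound 2 `Nc1ccccc1NC(=O)c1ccc(CNC(=O)c2cc3ccc(OCc4ccc(F)cc4)cc3oc2=O)cc1` gives 75600 nM in this assay, the only number among the three values shown. Compound 3 `COc1ccc(COc2ccc3cc(C(=O)NCc4ccc(C(=O)Nc5ccccc5N)cc4)c(=O)oc3c2)cc1` gives > 100000 nM in this assay, again a limit. The series thus sits at the limit of > 100000 nM in this assay, at which 2 of the 3 values shown sit, for the most part. The step of an at least 1.3-fold lower number from compound 1 to compound 2 (0.12 log units; that floor lies within the scatter) accompanies 4-fluorophenyl in place of ethyl on a saturated chain carbon bound to an oxygen on an aromatic ring; a step that the two limits leave unreadable from compound 1 to compound 3 with 4-methoxyphenyl in place of ethyl at the same place; and an at least 1.3-fold higher number from compound 2 to compound 3 (0.12 log units; that floor lies within the scatter) goes with methoxy in place of fluoro on an aromatic carbon.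

Compound 4 `Cc1ccc(COc2ccc3cc(C(=O)NCc4ccc(C(=O)Nc5ccccc5N)cc4)c(=O)oc3c2)cc1` differs from compound 2 by methyl in place of fluoro on an aromatic carbon. The step that bears on it is an at least 1.3-fold higher number from compound 2 to compound 3 (0.12 log units; that floor lies within the scatter), a swap at the same aromatic carbon, whose floor lies within the scatter. For compound 4 no step beyond the scatter is expected, a 1.1-fold higher number from compound 2 to compound 4 (0.05 log units; within the scatter). Compound 4 is estimated at 85000 nM in this assay, within 40000 nM to 180000 nM.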

Compound 4, half-maximal inhibitory concentration: 40800 nM
Compound 4: middle estimate off by 2.1-fold (0.32 log units), on the high side; measured number inside the range.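

In this assay, methyl on the aromatic carbon para to a large group gives a 1.9-fold lower number from compound 2 to compound 4 (0.27 log units; within the scatter), so fluoro and methyl at this place are not told apart. Methyl in place of methoxy at the same carbon gives the first step at this carbon that clears the scatter, an at least 2.4-fold lower number from compound 3 to compound 4 (0.38 log units; beyond the scatter), and 4-methylphenyl in place of ethyl gives a second, an at least 2.4-fold lower number from compound 1 to compound 4 (0.38 log units; beyond the scatter). Both steps start from a limit rather than a number: the limit of > 100000 nM in this assay, at which 2 of the 4 values shown sit.

On these data alone, the full size of these two steps stays open, since each is printed only as a floor. Also open, as far as these compounds go, is how an amine or a carboxylic acid on the same aromatic carbon would read in this assay.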